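Swapping the aryl group on the lowest compound of three

The source may hold more compounds than are shown below. What is called first, only, known or untested is meant among the compounds shown, and "the series" means these compounds.

Measured so far, in a functional assay on SK-N-SH cells (Homo sapiens) for inhibition, read by MTT assay, with a stated time of 72 h, tested at 50 uM; on this read-out higher numbers stand for more inhibition of growth at the one concentration tested and lower numbers for less inhibition of growth:
Compound 1 `C=CCc1ccc(OCc2cn(-c3ccc(C#N)cc3)nn2)c(O)c1`: 62.5%
Compound 2 `C=CCc1ccc(OCc2cn(-c3cc(OC)c(OC)c(OC)c3)nn2)c(O)c1`: 55.9%
Compound 3 `C=CCc1ccc(OCc2cn(-c3ccccc3Cl)nn2)c(O)c1`: 42.8%

Among these three, compound 3 stands lowest at 42.8%, and its distance to each of the others lies beyond the usual scatter. The next compound, compound 4 `C=CCc1ccc(OCc2cn(-c3ccc(OC)cc3)nn2)c(O)c1`, keeps the shared core and changes one group: 4-methoxyphenyl in place of 2-chlorophenyl on an aromatic nitrogen. The 4-methoxyphenyl group thus takes the place of the 2-chlorophenyl group on the aromatic nitrogen.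

Among the compounds with values here, only one measured step involves this same place. It is a number 19.7 percentage points lower from compound 1 to compound 3 (beyond the scatter), a modest change that replaces 4-cyanophenyl with 2-chlorophenyl. Compound 2, which also carries methoxy groups on its aryl group, gives 55.9%. Within the data shown here, both neighbours sit higher than compound 3, so a modest upward change in this assay seems likely, though no measured compound has this exact group.

The expected change is a number 11.2 percentage points higher from compound 3 to compound 4 (beyond the scatter). For compound 4 the estimated value is 54%, with an expected range from 41% to 67%.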

Compound 4, percent growth inhibition at one concentration: 68.5%
The estimate for compound 4 lay 14.5 percentage points below the measured number; the whole stated range lies below it.
By their numbers in this assay, from the lowest: compound 3; then compounds 2, 1 and 4 (each within the scatter of the next, the first and the last beyond it).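

In this assay, the group on the aromatic nitrogen proves able to move the number a long way, with 4-methoxyphenyl in place of 2-chlorophenyl giving a number 25.7 percentage points higher from compound 3 to compound 4 (beyond the scatter). Methoxy in place of cyano on an aromatic carbon gives a number 6 percentage points higher from compound 1 to compound 4 (within the scatter), so two quite different groups on the same aryl frame cannot be told apart on this read-out, and the earlier lone step gave no hint of that. Nothing measured here offers a reason for either step.

The compounds shown leave open whether the low number of compound 3 goes with the chlorine itself or with where it sits, which a 4-chlorophenyl or 2-methoxyphenyl group could separate. They also leave open whether an amine or a carboxylic acid on the aryl group would keep the number of compound 4 .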